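Pyrrolyl for Trifluoromethoxy on a Shared Core

The compounds below may be only part of what the source reports. "The series", "measured", "known", "first", "only" and "open" are said of these compounds alone.

Compound 1 `CN1C(=O)/C(=C(/S)N(C)c2ccccc2)C(=O)c2cc(Cl)ccc21` gives 64%; 64% (2 entries) in a functional assay on the whole organism for inhibition, with Mus musculus as the target, at a dose of 10 mg/kg by the oral route; on this read-out lower numbers stand for less inhibition and higher numbers for more inhibition at the one dose given (going by the name of the read-out).
Compound 2 `CN1C(=O)/C(=C(/S)N(C)c2ccccc2)C(=O)c2cc(Br)ccc21` gives 56% in this assay.
Compound 3 `CN1C(=O)/C(=C(/S)N(C)c2ccccc2)C(=O)c2cc(OC(F)(F)F)ccc21` gives 19% in this assay.

Compound 3 stands lowest of the two compounds with a single number; its nearest neighbour is compound 2, and the change a number 37 percentage points lower from compound 2 to compound 3 (beyond the scatter) lies beyond the scatter. Compound 1 sits with its two entries near compound 2.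

Compound 4 `CN1C(=O)/C(=C(/S)N(C)c2ccccc2)C(=O)c2cc(-n3cccc3)ccc21` has not been measured. It differs from compound 3 by 1H-pyrrol-1-yl in place of trifluoromethoxy on an aromatic carbon. Among the measured compounds shown here, the only measured step that bears on this position is the one from compound 2 to compound 3, where trifluoromethoxy in place of bromo brought a large fall. The new group is an aromatic ring rather than a halogen or a trifluoromethoxy, so that step gives only an indirect guide: the low value of compound 3 may not carry over, but nothing shows that the level of compounds 1 and 2 would be regained either. An upward step is therefore expected for compound 4, of uncertain size, as a number 16 percentage points higher from compound 3 to compound 4 (beyond the scatter). The estimate for compound 4 is 35%, with a range from 10% to 62%.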

Compound 4, a percentage reported as inhibition, in the whole organism at one dose (the size of the read-out at that dose, not a potency): -10%
Beside the measured number, compound 4's estimate is 45 percentage points above it; the whole stated range lies above it.
By their numbers in this assay, from the lowest: compound 4; then compound 3; then compound 2.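

In this assay the change to 1H-pyrrol-1-yl on this aromatic carbon did not recover the read-out but lowered it further, with a number 29 percentage points lower from compound 3 to compound 4 (beyond the scatter) even though both groups carry the same count of heavy atoms. Measured against bromo, the same group gave a number 66 percentage points lower from compound 2 to compound 4 (beyond the scatter), a larger fall than the one trifluoromethoxy brought, so compound 4 stands lowest of the compounds with a single number and shows that this position can take the read-out down to a negative number. No measurement is at hand that explains why this group lowers the read-out here.

What the compounds shown leave open is how a fluoro, a methoxy or an amine on this aromatic carbon would read out. From the compounds shown here alone, it also remains open whether a phenyl ring would follow 1H-pyrrol-1-yl or come closer to the halogens.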